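A few compounds are considered here, and "the series" means these few. Any claim that something is new, unique, unknown or untested is made for them only; others in the source may bear on it.

Of the compounds shown here, three built on one shared core have been tested in an assay on membranes from brain for displacement of a labelled ligand from Neuronal acetylcholine receptor; alpha4/beta2 (Rattus norvegicus); on this read-out lower numbers stand for stronger inhibition and higher numbers for weaker inhibition. Compound 1 `CN1CCC[C@H]1COc1cccnc1` gives 0.15 nM. Compound 2 `CN1CCC[C@H]1COc1cncc(Cl)c1` gives 0.6 nM, and compound 3 `CC(C)Cc1cncc(OC[C@@H]2CCCN2C)c1` gives 0.21 nM. Compound 3 thus stands second highest of the three numbers; the nearer gap, a 1.4-fold higher number from compound 1 to compound 3 (0.15 log units; within the scatter), lies within the scatter, while the wider one, a 2.9-fold lower number from compound 2 to compound 3 (0.46 log units; beyond the scatter), lies beyond it.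

Compound 4 `CC(=O)c1cncc(OC[C@@H]2CCCN2C)c1` differs from compound 3 in a single place: acetyl in place of isobutyl on an aromatic carbon. Going by the values given here, no measured step puts an acetyl group on this core, so the expectation rests on what other groups on the same aromatic carbon have done. Replacing hydrogen by isobutyl stayed within the scatter, a 1.4-fold higher number from compound 1 to compound 3 (0.15 log units; within the scatter), whereas replacing hydrogen by chloro raised the number, a 4.0-fold higher number from compound 1 to compound 2 (0.60 log units; beyond the scatter), and going from chloro to isobutyl lowered it again, a 2.9-fold lower number from compound 2 to compound 3 (0.46 log units; beyond the scatter). Groups on this carbon have so far shifted the number by modest amounts at most, in either direction. On that basis compound 4 is expected to give a somewhat higher number than compound 3, a step of about a 2.4-fold higher number from compound 3 to compound 4 (0.38 log units; beyond the scatter), though a result within the scatter would not be surprising. The estimate for compound 4 in this assay is 0.5 nM, with a range from 0.15 nM to 2 nM.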

Compound 4, inhibition constant: 1.19 nM
Compound 4: the middle estimate sits 2.4-fold (0.38 log units) below what was measured; the measured number falls inside the stated range.
By their numbers in this assay, from the lowest: compounds 1 and 3 (each within the scatter of the next); then compounds 2 and 4 (each within the scatter of the next).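

In this assay, the step from isobutyl to acetyl (a 5.7-fold higher number from compound 3 to compound 4 (0.75 log units; beyond the scatter)) shows that this aromatic carbon, two atoms from the ring nitrogen, does not treat all carbon-based groups alike: a group of four carbons gave way to one of three heavy atoms carrying a carbonyl and a hydrogen-bond acceptor, and the number moved beyond the scatter. Acetyl also stands clear of hydrogen (a 7.9-fold higher number from compound 1 to compound 4 (0.90 log units; beyond the scatter)), while it cannot be told apart from chloro (a 2.0-fold higher number from compound 2 to compound 4 (0.30 log units; within the scatter)), so two of the three groups on this carbon raise the number relative to hydrogen, with isobutyl going against that trend. No measurement at hand accounts for why acetyl and isobutyl differ here.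

The compounds shown leave open whether the rise goes with the carbonyl itself or with the loss of the isobutyl carbons, a question that an ethyl or a hydroxyethyl group on the same carbon would help to separate. They also leave open whether an amine or a carboxylic acid here would fall with acetyl and chloro or with hydrogen and isobutyl.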